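The compounds below may be only part of what the source reports. "The series", "measured", "known", "first", "only" and "open" are said of these compounds alone.

Measured so far in a functional assay on the whole organism (strain NMRI) for inhibition, with Mus musculus as the target, in the formalin test, with a stated time of 30 min, at a dose of 30 umol/kg by the intraperitoneal route; a lower number here means less inhibition, a higher number more inhibition at the dose given (going by the name of the read-out): compound 1 `[O-][S+](c1ccccc1)c1ccccc1-c1n[nH]c(=S)o1` gives 86.1%; compound 2 `Nc1nnc(-c2ccccc2[S+]([O-])c2ccccc2)o1` gives 79.9%.

Compound 2 holds the smaller of the two numbers, but its distance from compound 1 is a number 6.2 percentage points lower from compound 1 to compound 2 (within the scatter), within the scatter, so the two cannot be told apart on this assay.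

Compound 3 `[O-][S+](c1ccccc1)c1ccccc1-c1n[nH]c(=S)[nH]1` is not yet measured. Its change from compound 2: a group of 6 heavy atoms (2 carbon, 3 nitrogen, 1 sulfur; one five-membered aromatic ring with 3 hetero atoms) in place of a group of 6 heavy atoms (2 carbon, 3 nitrogen, 1 oxygen; one five-membered aromatic ring with 3 hetero atoms), on an aromatic carbon. Going by the values given here, the only step known, from compound 1 to compound 2, also swapped one five-membered aromatic ring with 3 hetero atoms for another on the same aromatic carbon and moved the read-out by a number 6.2 percentage points lower from compound 1 to compound 2 (within the scatter). Compound 3 brings back a sulfur-bearing ring of the kind compound 1 carries, so no step beyond the scatter is expected; the estimated step is a number 2.1 percentage points higher from compound 2 to compound 3 (within the scatter). Compound 3 is therefore estimated at 82%, within the range 65% to 95%.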

Compound 3, a percentage reported as inhibition, in the whole organism at one dose (the size of the read-out at that dose, not a potency): 63.3%
Compound 3: the middle estimate sits 18.7 percentage points above what was measured; the whole stated range lies above it.
By their numbers in this assay, from the lowest: compound 3; then compounds 2 and 1 (each within the scatter of the next).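

In this assay, going by these compounds alone, this aromatic carbon proves sensitive to the choice of ring: exchanging the 5-amino-1,3,4-oxadiazol-2-yl group for the entering ring gives a number 16.6 percentage points lower from compound 2 to compound 3 (beyond the scatter) and is the first step at this position to clear the scatter. The sulfur-bearing ring of compound 1 gives no protection, since replacing it with the entering ring, which also carries sulfur and has nitrogen where compound 1 has ring oxygen, gives a number 22.8 percentage points lower from compound 1 to compound 3 (beyond the scatter) in the same direction. Nothing available explains this loss of inhibition.

Within the data shown here, with only three rings compared, it remains open whether the ring itself is needed at this position. Going by these compounds, a carboxylic acid or a methyl ester on the same aromatic carbon would test that, while the part of the core outside this position also remains unexplored.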